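This account rests on a few compounds, and the source may have more. Where it says the series, first, only, none or still open, it means among the compounds named here.

Series notes. Compound 1 `COC1Cc2sccc2C2(CCN(CCCc3ccccc3)CC2)O1` and compound 2 `CCCCN1CCC2(CC1)OC(OC)Cc1sccc12` share one core and differ only in the chain carried by the amine nitrogen in a ring. In an assay on membranes from brain for displacement of a labelled ligand from Sigma non-opioid intracellular receptor 1 (Cavia porcellus) (a lower number here means a stronger inhibitor, a higher number a weaker inhibitor), compound 1 gives 2.4 nM; in this assay compound 2 gives 4.3 nM. The step of a 1.8-fold higher number from compound 1 to compound 2 (0.25 log units; within the scatter) is within the scatter, so the two values cannot be ordered. Going by the values given here, compound 2 thus holds the higher of the two numbers, with compound 1 its only neighbour and the gap within the scatter.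

Compound 3 `CCCCCN1CCC2(CC1)OC(OC)Cc1sccc12` is the next step: methyl in place of hydrogen on a saturated chain carbon, four bonds along the chain from an amine nitrogen in a ring. Among the compounds with values here, no measured pair repeats this change; the one step recorded, a 1.8-fold higher number from compound 1 to compound 2 (0.25 log units; within the scatter), concerns a different exchange on the same chain and stayed within the scatter. Within the data shown here, the series so far gives no footing for a step beyond the scatter in this assay in either direction. The step of a 1.2-fold lower number from compound 2 to compound 3 (0.09 log units; within the scatter) is therefore expected to stay within the scatter. Compound 3 is expected to give 3.5 nM, with a range of 1.2 nM to 10 nM.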

Compound 3, inhibition constant: 1.6 nM
Estimate against measurement, compound 3: 2.2-fold (0.34 log units) above; measured number inside the range.
By their numbers in this assay, from the lowest: compounds 3, 1 and 2 (each within the scatter of the next, the first and the last beyond it).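

In this assay, going by these compounds alone, methyl in place of hydrogen on a saturated chain carbon, four bonds along the chain from an amine nitrogen in a ring, gives a 2.7-fold lower number from compound 2 to compound 3 (0.43 log units; beyond the scatter) and is the first step beyond the scatter, though a modest one. Exchanging the chain carried by the amine nitrogen in a ring gives a 1.5-fold lower number from compound 1 to compound 3 (0.18 log units; within the scatter) and so leaves compound 1 and compound 3 unordered. Nothing at hand explains the size of either step.

Going by these compounds, whether a longer chain on the amine nitrogen in a ring would carry the step further remains open. So does the effect of a hydroxyl group or a carboxylic acid on that chain.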